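The source may report more compounds than this note shows. Statements on the series, on what has been measured and on what is new or still open speak of the compounds shown alone.

Compound 1 `O=C([C@@H]1CCCN(S(=O)(=O)c2ccc(S(=O)(=O)C3CCC3)cc2)C1)N1CCC(F)(F)CC1` gives 78 nM in a functional assay on BXPC-3 cells (Homo sapiens) for inhibition, read by MTT assay, with a stated time of 7 days (a higher number here means a weaker inhibitor, a lower number a stronger inhibitor), while compound 3 `O=C([C@@H]1CCCN(S(=O)(=O)c2ccc(S(=O)(=O)N3CC[C@H](O)C3)cc2)C1)N1CCC(F)(F)CC1` gives 580 nM and compound 2 `CCN(CC)S(=O)(=O)c1ccc(S(=O)(=O)N2CCC[C@@H](C(=O)N[C@H]3CCOC3)C2)cc1` gives 5270 nM. Compound 2 thus stands at the highest number of the three; its nearest neighbour is compound 3 and its furthest is compound 1. Going by the values given here, the only step measured in one place, a 7.4-fold higher number from compound 1 to compound 3 (0.87 log units; beyond the scatter), concerns a group on a sulfonyl sulfur and was modest. Compound 4 `CCN(CC)S(=O)(=O)c1ccc(S(=O)(=O)N2CCC[C@@H](C(=O)N3CC[C@H](OC)C3)C2)cc1` differs from compound 2 at the carbonyl carbon instead: 3-methoxypyrrolidin-1-yl in place of (oxolan-3-yl)amino on a carbonyl carbon. Among the compounds with values here, no measured step touches this position, and the gap between compound 2 and compound 1, which carries a different group on both the carbonyl and the sulfonyl, cannot be attributed to either. Compound 1 and compound 3, both without a hydrogen-bond donor at the carbonyl, sit at lower numbers than compound 2, so a small move downward is expected for compound 4, a 2.1-fold lower number from compound 2 to compound 4 (0.32 log units; beyond the scatter), with considerable uncertainty. Compound 4 is estimated at 2500 nM, within 700 nM to 9000 nM.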

Compound 4, half-maximal inhibitory concentration: 6750 nM
Compound 4: middle estimate off by 2.7-fold (0.43 log units), on the low side; the measured number falls inside the stated range.
By their numbers in this assay, from the lowest: compound 1; then compound 3; then compounds 2 and 4 (each within the scatter of the next).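

In this assay, going by these compounds alone, the first measured step at this position, 3-methoxypyrrolidin-1-yl in place of (oxolan-3-yl)amino on a carbonyl carbon, gives a 1.3-fold higher number from compound 2 to compound 4 (0.11 log units; within the scatter). The change removes the amide hydrogen and adds one heavy atom while keeping a five-membered non-aromatic ring and the oxygen, yet the assay does not separate the two compounds, so in this pair the loss of the hydrogen-bond donor leaves no readable mark. Nothing available here explains why the two compounds read alike.

The compounds shown leave open whether this exchange would read the same with cyclobutyl on the sulfonyl sulfur, where the core of compound 1 gives a much lower number. They also leave open what a primary amine, a carboxylic acid or a longer alkyl chain would give on this carbonyl carbon.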